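Swapping a pyridinyl-ethenyl arm for a methoxyphenyl ring

The source may report more compounds than this note shows. Statements on the series, on what has been measured and on what is new or still open speak of the compounds shown alone.

Within the data shown here, compound 3 `COC(=O)/C=C/c1cccc(N(Cc2ccc(/C=C/c3ccccn3)cc2)C(=O)C(C)C)c1` gives 310 nM in an assay on isolated protein with Bile acid receptor (Homo sapiens) as the target (on this read-out higher numbers stand for an effect only at larger amounts of compound and lower numbers for an effect already at smaller amounts), the highest of the three numbers measured so far: compound 2 `COC(=O)/C=C/c1cccc(N(Cc2ccc(/C=C/c3ccc(F)cc3)cc2)C(=O)C(C)C)c1` gives 120 nM and compound 1 `COC(=O)/C=C/c1cccc(N(Cc2ccc(/C=C/c3c(F)cccc3F)cc2)C(=O)C(C)C)c1` gives 108 nM. Compound 4 `COC(=O)/C=C/c1cccc(N(Cc2ccc(-c3ccc(OC)cc3)cc2)C(=O)C(C)C)c1` differs from compound 3 by 4-methoxyphenyl in place of 2-(pyridin-2-yl)ethenyl on an aromatic carbon. Among the measured compounds shown here, none of the measured steps removes the double-bonded chain; they only exchange the ring at its end, with a 1.1-fold higher number from compound 1 to compound 2 (0.05 log units; within the scatter), a 2.9-fold higher number from compound 1 to compound 3 (0.46 log units; beyond the scatter) and a 2.6-fold higher number from compound 2 to compound 3 (0.41 log units; beyond the scatter). The all-carbon rings of compound 1 and compound 2 gave lower numbers than compound 3. From the compounds shown here alone, a small decrease is therefore expected for compound 4, a 1.8-fold lower number from compound 3 to compound 4 (0.26 log units; within the scatter), although the shortened link is untested. Compound 4 is estimated at 170 nM, between 60 nM and 450 nM.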

Compound 4, half-maximal effective concentration: 97 nM
Estimate against measurement, compound 4: 1.8-fold (0.24 log units) above; measured number inside the range.
By their numbers in this assay, from the lowest: compounds 4, 1 and 2 (each within the scatter of the next); then compound 3.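

In this assay, a ring joined directly to the core does as well as the ethenyl arms with all-carbon rings, giving (a 1.2-fold lower number from compound 2 to compound 4 (0.09 log units; within the scatter)) and (a 1.1-fold lower number from compound 1 to compound 4 (0.05 log units; within the scatter)). So the double-bonded link is not required at this position for numbers of this size. The one step beyond the scatter is (a 3.2-fold lower number from compound 3 to compound 4 (0.50 log units; beyond the scatter)), which leaves the 2-(pyridin-2-yl)ethenyl arm alone with the higher number among these compounds.

Nothing available explains this difference.
Compound 3 and compound 4 differ in both ring and link, so a pyridin-2-yl ring joined directly, or a carboxylic acid in place of the methoxy group, would be needed to separate these effects.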